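A few compounds are considered here, and "the series" means these few. Any claim that something is new, unique, unknown or untested is made for them only; others in the source may bear on it.

Measured so far:
compound 1, `COc1ccc(C2N=C(SCc3ccc(Cl)cc3)NC(C)=C2C(=O)Nc2ccc(Br)cc2)cc1` — in a functional assay on the whole organism (artery, strain albino) with Rattus norvegicus as the target, with a stated time of 15 min, at a dose of 10 mg/kg by the oral route (a lower number here means less inhibition, a higher number more inhibition at the dose given (going by the name of the read-out)), compound 1 gives 3.1%
compound 2, `CC1=C(C(=O)Nc2ccc([N+](=O)[O-])cc2)C(c2ccc(Br)cc2)N=C(SCc2ccccc2Cl)N1` — in this assay compound 2 gives 1.5%
compound 3, `CC1=C(C(=O)Nc2ccc([N+](=O)[O-])cc2)C(c2cccc([N+](=O)[O-])c2)N=C(SCc2ccccc2Cl)N1` — in this assay compound 3 gives 2.1%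

All three numbers sit low and close together. Compound 3 holds the second highest of the three values; its nearest neighbour is compound 2, with the step of a number 0.6 percentage points higher from compound 2 to compound 3 (within the scatter), and compound 1 lies only a little above it, so nothing here separates the three compounds beyond the usual scatter.

Compound 4, `CC1=C(C(=O)Nc2ccc([N+](=O)[O-])cc2)C(c2cccc([N+](=O)[O-])c2)N=C(SCc2ccc(F)cc2)N1`, keeps the whole core of compound 3 and changes only the group on the sulfur side: 4-fluorophenyl in place of 2-chlorophenyl on a saturated chain carbon bound to a sulfur. Going by the values given here, no measured pair differs at this place, so no step bears directly on it. Among the compounds with values here, the one step that is available, a number 0.6 percentage points higher from compound 2 to compound 3 (within the scatter), concerns a different part of the molecule and was small. Compound 1 carries a 4-chlorophenyl on the carbon bound to sulfur but differs from compound 3 elsewhere as well, so only its value can be compared, and it is near that of compound 3. Given that every change seen so far left the read-out at the low end, the expectation for compound 4 is a step of a number 0.4 percentage points higher from compound 3 to compound 4 (within the scatter), that is, none beyond the scatter. Compound 4 is therefore estimated at 2.5%, in the range 0% to 12%.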

Compound 4, a percentage reported as inhibition, in the whole organism at one dose (the size of the read-out at that dose, not a potency): 2.6%
Compound 4: middle estimate off by 0.1 percentage points, on the low side, and the stated range covers the measured number.
By their numbers in this assay, from the lowest: compounds 2, 3, 4 and 1 (each within the scatter of the next).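

Going by these compounds alone, this pair gives the first direct reading at the saturated chain carbon bound to a sulfur: in this assay, 4-fluorophenyl in place of 2-chlorophenyl gives a number 0.5 percentage points higher from compound 3 to compound 4 (within the scatter), even though the halogen and its ring position differ at once. With the earlier step at the saturated ring carbon, a number 0.6 percentage points higher from compound 2 to compound 3 (within the scatter), changes at two separate places have now been read, and neither goes beyond the scatter, so neither place yet shows any influence on the read-out. The measurements shown offer nothing that could explain this result.

Going by these compounds, the two groups compared at the sulfur side are both halogen-bearing phenyl rings, so it remains open whether a different kind of group on this carbon, such as a carboxylic acid, an amine or a longer alkyl chain, would give a reading beyond the scatter. On these data alone, it is also open whether any compound of this series can be separated from the others at all, as each of the four values lies within the scatter of the next.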